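Compound 3 loses its second aromatic ring

The source may hold more compounds than are shown below. What is called first, only, known or untested is meant among the compounds shown, and "the series" means these compounds.

In a functional assay on HOS-TE85 cells (Homo sapiens) for inhibition, read by CCK-8 assay, with a stated time of 72 h (on this read-out lower numbers stand for stronger inhibition and higher numbers for weaker inhibition), compound 1 (`O=C(NCCCCc1ccccc1)c1cccc(C2SCC(=O)N2c2ccccc2)c1`) gives 15.9 nM and compound 3 (`O=C(NCCCCc1ccccc1)c1cccc(C2SCC(=O)N2c2cccc(-c3c[nH]nn3)c2)c1`) gives 110 nM as the higher of the two numbers. Compound 2 (`O=C(NCCCCc1ccccc1)c1cccc(C2SCC(=O)N2c2ccc(-c3ccccc3)cc2)c1`) gives > 1000 nM and this is a limit of the assay, not a number.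

Compound 4 (`COc1c(F)cccc1N1C(=O)CSC1c1cccc(C(=O)NCCCCc2ccccc2)c1`) has not been measured. It differs from compound 3 in one place (a group of 9 heavy atoms (7 carbon, 1 oxygen, 1 fluorine; one six-membered aromatic ring of carbon only) in place of a group of 11 heavy atoms (8 carbon, 3 nitrogen; one five-membered aromatic ring with 3 hetero atoms, one six-membered aromatic ring of carbon only), on an amide-type nitrogen in a ring), where 3-fluoro-2-methoxyphenyl enters on an amide-type nitrogen in a ring. For the measured compounds named here, three measured steps bear on this. Phenyl in place of hydrogen gave a large step (an at least 62-fold higher number from compound 1 to compound 2 (1.79 log units; beyond the scatter)). 1H-1,2,3-triazol-4-yl in place of hydrogen gave a modest one (a 6.9-fold higher number from compound 1 to compound 3 (0.84 log units; beyond the scatter)). Exchanging these two ring-bearing groups gave a further step (an at least 9.0-fold lower number from compound 2 to compound 3 (0.95 log units; beyond the scatter)).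

Like compound 1, compound 4 has no second ring on that nitrogen, so part of the rise to compound 3 (a 6.9-fold higher number from compound 1 to compound 3 (0.84 log units; beyond the scatter)) is expected to reverse. Going by the values given here, no measured compound carries its fluoro or methoxy groups, so the expectation is loose. A modest step toward a lower number is expected (a 2.2-fold lower number from compound 3 to compound 4 (0.34 log units; beyond the scatter)). For compound 4 the estimated value is 50 nM with an expected range from 8 nM to 300 nM in this read-out.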

Compound 4, half-maximal inhibitory concentration: 26.2 nM
Compound 4: the middle estimate sits 1.9-fold (0.28 log units) above what was measured; measured number inside the range.
By their numbers in this assay, from the lowest: compounds 1 and 4 (each within the scatter of the next); then compound 3. At a limit, above all of these: compound 2.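

In this assay the substituted ring of compound 4 takes the place of the plain phenyl on the amide-type nitrogen with no change beyond the scatter (a 1.6-fold higher number from compound 1 to compound 4 (0.22 log units; within the scatter)), so this position accepts fluoro and methoxy groups together, whereas the two additions seen earlier, phenyl and 1H-1,2,3-triazol-4-yl, both raised the number. The two groups with a second aromatic ring on this nitrogen both give higher numbers than the single-ring group of compound 4 (a 4.2-fold lower number from compound 3 to compound 4 (0.62 log units; beyond the scatter)) and (an at least 38-fold lower number from compound 2 to compound 4 (1.58 log units; beyond the scatter)). Compound 2 carries a limit of the assay, not a number: the limit of > 1000 nM in this assay, at which 1 of the 4 values shown sits.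

From the compounds shown here alone, what fluoro and methoxy each contribute alone remains open, since they appear only together. Also open, going by these compounds, is how this position would respond to a carboxylic acid or an amine on the phenyl ring, or to a pyridine ring in its place.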